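Cyclopropyl for Ethyl and the Cytotoxicity Ceiling

The source may report more compounds than this note shows. Statements on the series, on what has been measured and on what is new or still open speak of the compounds shown alone.

Compound 1 `CCNc1cc(Oc2c(OC)cc3cc(C#N)ccc3c2OC)nc(Nc2ccc(C#N)cc2)n1` carries an ethyl group on a nitrogen attached to the shared core. In an ADME assay on MT4 cells (Homo sapiens) for cytotoxicity, read by MTT assay, with a stated time of 5 days (on this read-out higher numbers stand for lower toxicity in this test and lower numbers for higher toxicity in this test), compound 1 gives > 125000 nM, which is a limit of the assay and not a measured number. Two close relatives have been tested in this assay. Compound 2 `COc1cc2cc(C#N)ccc2c(OC)c1Oc1cc(NC(C)C)nc(Nc2ccc(C#N)cc2)n1` carries methyl in place of hydrogen on a saturated chain carbon bound to a nitrogen on an aromatic ring and a saturated chain carbon; in this assay compound 2 gives > 125000 nM, again a limit. Compound 3 `CCC(CC)Nc1cc(Oc2c(OC)cc3cc(C#N)ccc3c2OC)nc(Nc2ccc(C#N)cc2)n1` carries pentan-3-yl in place of ethyl on a nitrogen on an aromatic ring; in this assay compound 3 gives > 125000 nM, also a limit. Because of the limit of > 125000 nM in this assay, at which 3 of the 3 values shown sit, the steps a step that the two limits leave unreadable from compound 1 to compound 2, a step that the two limits leave unreadable from compound 1 to compound 3 and a step that the two limits leave unreadable from compound 2 to compound 3 cannot be sized.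

Compound 4 `COc1cc2cc(C#N)ccc2c(OC)c1Oc1cc(NC2CC2)nc(Nc2ccc(C#N)cc2)n1` is the next variation, differing from compound 1 by cyclopropyl in place of ethyl on a nitrogen on an aromatic ring. The three measured steps all fall between limits and therefore give no direction or size for the change to compound 4. Compound 4 is expected to reach only a limit as well, estimated at 125000 nM with a range from 60000 nM to 250000 nM. The expected step of a number no higher from compound 1 to compound 4 (the limit leaves the size open) is therefore no change beyond the scatter.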

Compound 4, half-maximal cytotoxic concentration: > 125000 nM
Compound 4: a limit, no number; the forecaster's own chance of this, stated with the estimate: 85%; the middle value lies on the limit itself.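

None of the steps from compound 1, compound 2 or compound 3 to compound 4 can be read, because all four compounds stop at the same limit: the limit of > 125000 nM in this assay, at which 4 of the 4 values shown sit.

The compounds shown leave open at what concentration any of them would become toxic in this assay, and whether ethyl, isopropyl, pentan-3-yl and cyclopropyl differ in that respect.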